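The source may report more compounds than this note shows. Statements on the series, on what has been measured and on what is new or still open speak of the compounds shown alone.

Measured compounds in a functional assay on MCF cells (Homo sapiens) for antiproliferative activity, with a stated time of 72 h (on this read-out lower numbers stand for stronger inhibition and higher numbers for weaker inhibition), each value being a limit of the assay and not a number:

- Compound 1 `Cc1cccc(CNc2ncnc3c2ncn3[C@@H]2O[C@H](CO)[C@@H](O)[C@H]2O)c1`: > 166000 nM
- Compound 2 `COc1ccccc1CNc1ncnc2c1ncn2[C@@H]1O[C@H](CO)[C@@H](O)[C@H]1O`: > 166000 nM
- Compound 3 `COc1cccc(CNc2ncnc3c2ncn3[C@@H]2O[C@H](CO)[C@@H](O)[C@H]2O)c1`: > 166000 nM

Compound 3 has no numerical value in this assay, only a limit, and it shares that position with the other two compounds: the limit of > 166000 nM in this assay, at which 3 of the 3 values shown sit. Compound 4 `OC[C@H]1O[C@@H](n2cnc3c(NCc4cccc(OC(F)(F)F)c4)ncnc32)[C@H](O)[C@@H]1O` differs from it by one change, (trifluoromethyl in place of methyl on an oxygen on an aromatic ring). In words, this is methoxy to trifluoromethoxy, with trifluoromethyl in place of methyl on an oxygen on an aromatic ring.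

Among the compounds with values here, none of the measured steps involves this change, and none gives a size to go on. The closest is a step that the two limits leave unreadable from compound 1 to compound 3. The other two are a step that the two limits leave unreadable from compound 1 to compound 2 and a step that the two limits leave unreadable from compound 2 to compound 3. So the data support no expected direction, and compound 4 is expected to stay in the same region, most likely reported as a limit again. The expected change is a number no higher from compound 3 to compound 4 (the limit leaves the size open). For compound 4 the estimated value is 166000 nM, with an expected range from 60000 nM to 300000 nM.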

Compound 4, half-maximal inhibitory concentration: > 166000 nM
Compound 4: no number, only a limit (the forecaster's own chance of this, stated with the estimate: 80%); the middle value lies on the limit itself.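

In this assay compound 4 gives > 166000 nM, again a limit and not a number. The steps to it from compound 1 and compound 3 cannot be read. The compounds shown leave open whether any of these changes alters antiproliferative activity at all: the limit of > 166000 nM in this assay, at which 4 of the 4 values shown sit.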